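A few compounds are considered here, and "the series" means these few. Any claim that something is new, unique, unknown or untested is made for them only; others in the source may bear on it.

Series notes. Compound 1 `c1ccc(-c2cnnc(NCc3cc(-c4ccccc4)[nH]n3)n2)cc1`, compound 2 `Cc1cccc(-c2cnnc(NCc3cc(-c4ccccc4)[nH]n3)n2)c1` and compound 3 `Cc1ccccc1-c1cccc(NCc2cc(-c3ccccc3)[nH]n2)n1` share one core; compound 4 `Cc1cc(C#N)ccc1-c1cnnc(NCc2cc(-c3ccccc3)[nH]n2)n1` has not yet been measured. In an ADME assay on CEM174 cells (Homo sapiens) for cytotoxicity (a lower number here means that less compound is tolerated, a higher number that more compound is tolerated), compound 1 gives > 10000 nM, which is a limit of the assay and not a number. In this assay compound 2 gives > 10000 nM, again a limit. In this assay compound 3 gives > 10000 nM, also a limit. Compound 2 thus stands at the same limit as the two further values shown, namely (the limit of > 10000 nM in this assay, at which 3 of the 3 values shown sit). The step that the two limits leave unreadable from compound 1 to compound 2 is not readable, both of its ends being limits.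

Compound 4 differs from compound 2 by 4-cyano-2-methylphenyl in place of 3-methylphenyl on an aromatic carbon. Within the data shown here, the only measured step that touches this position, a step that the two limits leave unreadable from compound 1 to compound 2, gives no size, so no magnitude for the step in this assay can be taken from it; the three limits show only that no measured compound of the series reaches the read-out within the tested range. The expectation is that the change from compound 2 to compound 4 gives no step beyond the scatter in this assay, that is a step that the limit leaves unreadable from compound 2 to compound 4. Compound 4 is expected at 15000 nM, in a range from 7000 nM to 40000 nM, and most likely it will again be reported only as a limit.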

Compound 4, half-maximal cytotoxic concentration: > 10000 nM
Compound 4: a limit, no number; the forecaster's own chance of this, stated with the estimate: 85%; the middle value is on the limit's open side.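

In this assay compound 4 gives > 10000 nM, a limit and not a number. The steps to compound 4 from compound 1 and compound 2 therefore cannot be read, and the series sits at one value: the limit of > 10000 nM in this assay, at which 4 of the 4 values shown sit.

The compounds shown leave open where the half-maximal cytotoxic concentration of each lies and whether any of these aromatic groups changes it.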